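From Ethyl to 4-Fluorobenzyl on the Sulfur Chain

This account rests on a few compounds, and the source may have more. Where it says the series, first, only, none or still open, it means among the compounds named here.

Measured in a functional assay on PC-3 cells (Homo sapiens) for inhibition, read by MTT assay, with a stated time of 48 h; a higher number here means a weaker inhibitor, a lower number a stronger inhibitor:
- Compound 1 `CCSc1nnc(-c2cc(OC)c(OC)c(OC)c2)n1-c1ccc(OC)cc1`: 57700 nM
- Compound 2 `COc1ccc(-n2c(SCC(=O)c3ccc(OC)c(O)c3)nnc2-c2cc(OC)c(OC)c(OC)c2)cc1`: > 60000 nM, a limit of the assay and not a number
- Compound 3 `CCSc1nnc(-c2cc(OC)c(OC)c(OC)c2)n1-c1ccc(N(C)C)cc1`: 46200 nM

Compound 3 and compound 1 cannot be told apart, as a 1.2-fold lower number from compound 1 to compound 3 (0.10 log units; within the scatter) shows. Both are weak inhibitors in this assay.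

Compound 4 `COc1cc(-c2nnc(SCc3ccc(F)cc3)n2-c2ccc(N(C)C)cc2)cc(OC)c1OC` keeps the rest of compound 3 but places 4-fluorophenyl in place of methyl on a saturated chain carbon bound to a sulfur, turning ethyl into 4-fluorobenzyl: 4-fluorophenyl in place of methyl on a saturated chain carbon bound to a sulfur.

Within the data shown here, the one measured change at this place is an at least 1.0-fold higher number from compound 1 to compound 2 (0.01 log units; that floor lies within the scatter). It ends at a limit, so it gives only a floor and no true size, and its group differs from 4-fluorophenyl. The change from compound 1 to compound 3 lies elsewhere on the molecule and says little here. With so little to go on, no shift beyond the scatter is expected, and the expected step is a 1.1-fold lower number from compound 3 to compound 4 (0.04 log units; within the scatter).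

Compound 4 is estimated at 42000 nM, with an expected range of 14000 nM to 75000 nM.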

Compound 4, half-maximal inhibitory concentration: 46500 nM
Estimate against measurement, compound 4: 1.1-fold (0.04 log units) below, within the range that was stated.
By their numbers in this assay, from the lowest: compounds 3, 4 and 1 (each within the scatter of the next). At a limit, above all of these: compound 2.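

In this assay the change from ethyl to 4-fluorobenzyl on the sulfur chain puts 7 heavy atoms and an aromatic ring where methyl stood, and it gives a 1.0-fold higher number from compound 3 to compound 4 (0.00 log units; within the scatter) as its whole effect. Among these compounds, the earlier change at this place ended at a limit and gave only a floor, so this is the first true size for a step here: a much larger group on a saturated chain carbon bound to a sulfur leaves the number where it was, and the compounds remain weak inhibitors. Compound 2 remains a limit of the assay and not a number: the limit of > 60000 nM in this assay, at which 1 of the 4 values shown sits.

Going by these compounds, whether any group at this place can move the number beyond the scatter stays open. An amine or a carboxylic acid on the sulfur chain, or a longer alkyl chain, could answer that, and a plain benzyl group would show whether the fluorine matters.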